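This account rests on a few compounds, and the source may have more. Where it says the series, first, only, none or still open, it means among the compounds named here.

The measured compounds:

compound 1, `Cn1cc(S(=O)(=O)NC(=O)NC/C=C2\CCCc3cnn(Cc4ccc(Cl)cc4Cl)c32)cn1`, 9 nM
compound 2, `O=C(NC/C=C1\CCCc2cnn(-c3ccc(C(F)(F)F)cc3)c21)NS(=O)(=O)c1cc(Cl)c(Cl)s1`, 0.4 nM
compound 3, `Cc1ncc(S(=O)(=O)NC(=O)NC/C=C2\CCCc3cnn(Cc4ccc(Cl)cc4Cl)c32)s1`, 7 nM

In an assay on isolated protein for displacement of a labelled ligand from prostaglandin E2 receptor EP3 subtype (Homo sapiens), read by scintillation counting, with a stated time of 2 h (a lower number here means a stronger inhibitor, a higher number a weaker inhibitor), compound 1 gives 9 nM, compound 2 gives 0.4 nM and compound 3 gives 7 nM. Compound 3 thus holds the second highest of the three numbers; it sits within the scatter of compound 1 and well apart from compound 2, whose number is beyond the scatter lower.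

Compound 4, `O=C(NC/C=C1\CCCc2cnn(Cc3ccc(Cl)cc3Cl)c21)NS(=O)(=O)c1cc(Cl)c(Cl)s1`, differs from compound 3 in one place: 4,5-dichlorothiophen-2-yl in place of 2-methyl-1,3-thiazol-5-yl on a sulfonyl sulfur. One measured step alters the same position, a 1.3-fold lower number from compound 1 to compound 3 (0.11 log units; within the scatter), and it stayed within the scatter. Among the measured compounds shown here, compound 2 carries the same 4,5-dichlorothiophen-2-yl group on its sulfonyl sulfur and gives 0.4 nM, but it also differs from compound 4 at the other end of the core, so no single step connects the two, and only the two values can be compared.

Taken together, a lower number is expected for compound 4, a step of a 4.7-fold lower number from compound 3 to compound 4 (0.67 log units; beyond the scatter). The estimate for compound 4 in this assay is 1.5 nM, with a range from 0.4 nM to 6 nM.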

Compound 4, inhibition constant: 0.5 nM
Compound 4: the middle estimate sits 3.0-fold (0.48 log units) above what was measured; low and high end bracket the measured number.
By their numbers in this assay, from the lowest: compounds 2 and 4 (each within the scatter of the next); then compounds 3 and 1 (each within the scatter of the next).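

In this assay, the group on the sulfonyl sulfur proves able to move the number a long way: a 14-fold lower number from compound 3 to compound 4 (1.15 log units; beyond the scatter) and an 18-fold lower number from compound 1 to compound 4 (1.26 log units; beyond the scatter) are both large and beyond the scatter, whereas the earlier step at this position, a 1.3-fold lower number from compound 1 to compound 3 (0.11 log units; within the scatter), stayed within it. With 4,5-dichlorothiophen-2-yl on the sulfonyl sulfur, a 1.3-fold higher number from compound 2 to compound 4 (0.10 log units; within the scatter), so 2,4-dichlorobenzyl and 4-(trifluoromethyl)phenyl on the aromatic nitrogen lie within the scatter of each other. Nothing available here offers a reason for the large steps.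

From the compounds shown here alone, it remains open which part of the 4,5-dichlorothiophen-2-yl group carries the step: a plain thiophen-2-yl group or a dichlorophenyl group would separate the ring from the chlorine atoms. Going by these compounds, it is also open whether the two groups on the aromatic nitrogen would still lie this close with 2-methyl-1,3-thiazol-5-yl on the sulfonyl sulfur.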